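Pyridinyl for ethyl on a piperazine: cytotoxicity expectation

A few compounds are considered here, and "the series" means these few. Any claim that something is new, unique, unknown or untested is made for them only; others in the source may bear on it.

Measured compounds:
Compound 1, `Cc1ncc([N+](=O)[O-])n1CC(O)CSC(=S)N1CCCCC1`: 1400000 nM
Compound 2, `Cc1ncc([N+](=O)[O-])n1CC(O)CSC(=S)N(C)C`: > 5000000 nM
Compound 3, `CCN1CCN(CC(O)Cn2c([N+](=O)[O-])cnc2C)CC1`: 4940000 nM

Compound 1 (`Cc1ncc([N+](=O)[O-])n1CC(O)CSC(=S)N1CCCCC1`) is the reference against which the others are read. In a toxicity assay on HeLa cells (Homo sapiens) for cytotoxicity, read by MTT assay, with a stated time of 24 h (a higher number here means a weaker inhibitor, a lower number a stronger inhibitor), compound 1 gives 1400000 nM. Compound 2 (`Cc1ncc([N+](=O)[O-])n1CC(O)CSC(=S)N(C)C`) reaches only a limit of the assay, > 5000000 nM, and not a number. For the measured compounds named here, that limit, (the limit of > 5000000 nM in this assay, at which 1 of the 3 values shown sits), is the only one among the values shown. Going by the values given here, the one step between measured compounds, an at least 3.5-fold higher number from compound 1 to compound 2 (0.55 log units; beyond the scatter), concerns the thiocarbonyl end of the molecule.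

Compound 3 (`CCN1CCN(CC(O)Cn2c([N+](=O)[O-])cnc2C)CC1`) carries a piperazine instead of the dithiocarbamate. Of the two numbers recorded, compound 3 gives the higher, 4940000 nM, lying beyond the scatter from compound 1.

Compound 4 (`Cc1ncc([N+](=O)[O-])n1CC(O)CN1CCN(c2ccccn2)CC1`) differs from compound 3 by pyridin-2-yl in place of ethyl on an amine nitrogen in a ring. Among the compounds with values here, no measured step touches this position, and the step from compound 1 to compound 2 alters a different part of the molecule, so it offers no guide. Absent any bearing evidence, compound 4 is expected to stay near compound 3, with the step of a 1.4-fold lower number from compound 3 to compound 4 (0.15 log units; within the scatter) estimated to remain within the scatter. Compound 4 is therefore estimated at 3500000 nM, between 900000 nM and 10000000 nM.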

Compound 4, half-maximal inhibitory concentration: 1830000 nM
Estimate against measurement, compound 4: 1.9-fold (0.28 log units) above, within the range that was stated.
By their numbers in this assay, from the lowest: compounds 1 and 4 (each within the scatter of the next); then compound 3. At a limit, above all of these: compound 2.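

In this assay, the group on the amine nitrogen in the ring of the piperazine proves able to move the number: a 2.7-fold lower number from compound 3 to compound 4 (0.43 log units; beyond the scatter). For the compounds shown here, this is the only measured step at this position, as the earlier step concerned the thiocarbonyl end of the molecule, and it shows that pyridin-2-yl in place of ethyl gives a modest change towards a stronger inhibitor. The change brings in one six-membered aromatic ring with 1 hetero atom and 1 hydrogen-bond acceptor, but no measurement shown accounts for the step or separates these features from one another.

On these data alone, whether a phenyl group, which has a carbon where pyridin-2-yl has its ring nitrogen, would give a number close to that of compound 4 remains open, and so does whether a longer alkyl chain such as butyl would move the number away from that of compound 3. As far as these compounds go, it is also open whether pyridin-3-yl on the same nitrogen would behave as pyridin-2-yl does, since a single pair of compounds cannot show how far this step extends.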